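Swapping 4-chlorophenyl for 3-iodophenyl on the amide

The compounds below may be only part of what the source reports. "The series", "measured", "known", "first", "only" and "open" are said of these compounds alone.

Compound 1 `COc1cc2ncnc(Nc3ccc(NC(=O)c4ccc(C)cc4)cc3)c2cc1OC` gives 19000 nM
Compound 2 `COc1cc2ncnc(Nc3ccc(NC(=O)c4ccc(C(C)(C)C)cc4)cc3)c2cc1OC` gives > 100000 nM (a limit of the assay, not a number)
Compound 3 `COc1cc2ncnc(Nc3ccc(NC(=O)c4ccc(Cl)cc4)cc3)c2cc1OC` gives 30000 nM

All three share one core and differ only in the aromatic group on the amide carbonyl, and all were tested in a functional assay on MCF7 cells (Homo sapiens) for inhibition, read by MTT assay; a lower number here means a stronger inhibitor, a higher number a weaker inhibitor. Compound 3 stands close to the methyl compound: a 1.6-fold higher number from compound 1 to compound 3 (0.20 log units; within the scatter). Its gap to the tert-butyl compound is larger: an at least 3.3-fold lower number from compound 2 to compound 3 (0.52 log units; beyond the scatter).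

The next compound is compound 4 `COc1cc2ncnc(Nc3ccc(NC(=O)c4cccc(I)c4)cc3)c2cc1OC`, which carries 3-iodophenyl in place of 4-chlorophenyl on a carbonyl carbon. For the measured compounds named here, none of the measured compounds carries this group, so the measured steps guide only loosely. Exchanging methyl for chloro gave a 1.6-fold higher number from compound 1 to compound 3 (0.20 log units; within the scatter), while exchanging methyl for tert-butyl gave an at least 5.2-fold higher number from compound 1 to compound 2 (0.72 log units; beyond the scatter). Going by the values given here, only the steps involving compound 2 went beyond the scatter. In this assay, then, no step beyond the scatter is expected, although compound 2 leaves room for a much weaker result. The expected step is a 1.2-fold higher number from compound 3 to compound 4 (0.07 log units; within the scatter). For compound 4 the estimated value is 35000 nM. The expected range for compound 4 runs from 12000 nM to 100000 nM.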

Compound 4, half-maximal inhibitory concentration: 30000 nM
For compound 4 the middle estimate is 1.2-fold (0.07 log units) above the measured one; low and high end bracket the measured number.
By their numbers in this assay, from the lowest: compounds 1, 3 and 4 (each within the scatter of the next). At a limit, above all of these: compound 2.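

In this assay, replacing 4-chlorophenyl with 3-iodophenyl on the carbonyl carbon changes both the halogen and its place on the ring, yet the result is no change at the digits printed from compound 3 to compound 4 (within the scatter), and the comparison with the methyl compound gives a 1.6-fold higher number from compound 1 to compound 4 (0.20 log units; within the scatter), so a third group joins the two that could not be told apart. The pattern that these aromatic groups all read alike has one exception, the 4-(tert-butyl)phenyl group of compound 2, with an at least 3.3-fold lower number from compound 2 to compound 4 (0.52 log units; beyond the scatter). The value of compound 2 is a limit of the assay, not a number, so the true size of that gap stays unknown: the limit of > 100000 nM in this assay, at which 1 of the 4 values shown sits.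

Since compound 3 and compound 4 differ in both the halogen and its place, the compounds shown cannot separate these two changes, and either could hide an effect that the other cancels. As far as these compounds go, it also stays open whether a group of another kind on this ring, such as an amine or a carboxylic acid, would move the number beyond the scatter in either direction.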